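Replacing the 4-chlorophenyl group of a nitro compound

The source may hold more compounds than are shown below. What is called first, only, known or untested is meant among the compounds shown, and "the series" means these compounds.

- compound 1 `CC(=O)N1N=C(Nc2nc3ccc([N+](=O)[O-])cc3s2)CC1c1ccc(Cl)cc1`: 132 umol/kg
- compound 2 `CC(=O)N1N=C(Nc2nc3ccc(Cl)cc3s2)CC1c1ccc(Cl)cc1`: 79.5 umol/kg

In a functional assay on the whole organism (Hindlimb, strain albino) with Mus musculus as the target, in the maximal electroshock model, with a stated time of 0.5 h (a higher number here means that more compound is needed for the effect, a lower number that less compound is needed), compound 1 gives 132 umol/kg. Within the data shown here, it stands level with compound 2, its only measured neighbour, as the step between them shows: a 1.7-fold lower number from compound 1 to compound 2 (0.22 log units; within the scatter). Compound 3 `CC(=O)N1N=C(Nc2nc3ccc([N+](=O)[O-])cc3s2)CC1OC1=CC=C1` keeps the nitro group of compound 1 but differs at another place: a group of 5 heavy atoms (4 carbon, 1 oxygen; one four-membered non-aromatic ring of carbon only) in place of a group of 7 heavy atoms (6 carbon, 1 chlorine; one six-membered aromatic ring of carbon only), on a saturated ring carbon. This measured step is the only one available, and it swaps chloro for nitro on an aromatic carbon, so it does not touch the saturated ring carbon where compound 3 changes. Among the measured compounds shown here, no measured step covers the loss of the 4-chlorophenyl group, so neither a size nor a direction can be carried over. With nothing to suggest otherwise, no step beyond the scatter is expected, though with little confidence. The expected step is a 1.1-fold higher number from compound 1 to compound 3 (0.03 log units; within the scatter). For compound 3 the estimated value is 140 umol/kg, with an expected range from 50 umol/kg to 380 umol/kg.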

Compound 3, dose for half-maximal effect: 274 umol/kg
For compound 3 the middle estimate is 2.0-fold (0.29 log units) below the measured one; the range from low to high includes it.
By their numbers in this assay, from the lowest: compounds 2 and 1 (each within the scatter of the next); then compound 3.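

In this assay, the saturated ring carbon proves sensitive to what it carries: with the 4-chlorophenyl group replaced by the smaller group holding an oxygen and a four-membered carbon ring, the data show a 2.1-fold higher number from compound 1 to compound 3 (0.32 log units; beyond the scatter). This step is modest, but unlike a 1.7-fold lower number from compound 1 to compound 2 (0.22 log units; within the scatter) on the aromatic carbon, it lies beyond the scatter, so more compound is needed once the 4-chlorophenyl group has gone. No measurement shown here explains this outcome.

The entering group differs from the 4-chlorophenyl group in its ring, its oxygen and its lack of chlorine all at once, and these changes remain unseparated; a plain phenyl group at this carbon would begin to tell them apart. Also open, as far as these compounds go, is whether the same swap gives a similar step with chloro in place of nitro.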